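The compounds below may be only part of what the source reports. "The series", "measured", "known", "first", "only" and "open" are said of these compounds alone.

Measured in a functional assay on U-251 cells (Homo sapiens) for antiproliferative activity, read by MTT assay, with a stated time of 48 h; on this read-out higher numbers stand for weaker inhibition and lower numbers for stronger inhibition:
- compound 1 `COc1ccc(-c2nc3cccc(-c4cc(OC)c(OC)c(OC)c4)c3o2)cc1`: > 25000 nM (a limit)
- compound 2 `COc1cc(-c2cccc3nc(-c4ccc(Br)cc4)oc23)cc(OC)c1OC`: > 25000 nM (a limit)
- compound 3 `COc1cc(-c2cccc3nc(-c4ccc(C)cc4)oc23)cc(OC)c1OC`: 3200 nM

Within the data shown here, compound 3 holds the only actual number in this assay, at 3200 nM. The other two results are not numbers: the limit of > 25000 nM in this assay, at which 2 of the 3 values shown sit.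

Compound 4 `COc1cc(-c2cccc3nc(-c4cccc(C)c4)oc23)cc(OC)c1OC` moves the methyl group, as 3-methylphenyl in place of 4-methylphenyl on an aromatic carbon shows, with 3-methylphenyl in place of 4-methylphenyl on an aromatic carbon. The nearest evidence is an at least 7.8-fold lower number from compound 1 to compound 3 (0.89 log units; beyond the scatter) and an at least 7.8-fold lower number from compound 2 to compound 3 (0.89 log units; beyond the scatter), both beyond the scatter, while a step that the two limits leave unreadable from compound 1 to compound 2 cannot be read. These steps exchange one group for another, so they show that activity in this assay can depend on this aryl group. None of them moves a group around the ring, so they give its size only loosely. A modest change toward weaker inhibition is expected, possibly none beyond the scatter.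

The expected step is a 1.6-fold higher number from compound 3 to compound 4 (0.19 log units; within the scatter). For compound 4 the estimated value is 5000 nM, with an expected range of 1800 nM to 20000 nM.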

Compound 4, half-maximal inhibitory concentration: > 25000 nM
Compound 4: no number, only a limit; the forecaster's own chance of this, stated with the estimate: 25%; middle value at least 5.0-fold (0.69 log units) away from the limit.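

Moving the methyl group, so that 3-methylphenyl stands in place of 4-methylphenyl, gives an at least 7.8-fold higher number from compound 3 to compound 4 (0.89 log units; beyond the scatter) in this assay. The earlier steps shown here only exchanged one group for another, whereas here the atoms stay the same, so the place of the methyl group on this aryl ring alone separates the two results. The result for compound 4 is a limit and not a number, and the steps to it from compound 1 and compound 2 cannot be read, with limits at both ends: the limit of > 25000 nM in this assay, at which 3 of the 4 values shown sit.

On these data alone, how far compound 4 actually lies from compound 3 remains open. So does whether a 4-ethylphenyl or 4-chlorophenyl group at this position would also give a measurable number, as 4-methylphenyl does in compound 3.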